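The source may hold more compounds than are shown below. What is called first, only, known or untested is meant among the compounds shown, and "the series" means these compounds.

Working notes on the diaryl-thiophene amide series, in a functional assay on PC-3 cells (Homo sapiens) for inhibition, read by sulforhodamine B assay, with a stated time of 72 h; a higher number here means a weaker inhibitor, a lower number a stronger inhibitor.

Compound 1 `CC1CCN(C(=O)c2c(N)sc(-c3ccc(Cl)cc3)c2-c2ccc(Cl)cc2)CC1` gives 5750 nM in this assay. Compound 3 `CN1CCN(C(=O)c2c(N)sc(-c3ccc(Cl)cc3)c2-c2ccc(Cl)cc2)CC1` gives 13100 nM. Compound 2 `Nc1sc(-c2ccc(Cl)cc2)c(-c2ccc(Cl)cc2)c1C(=O)Nc1ccccc1` reaches only a limit of this assay, > 50000 nM, and no number; this is the limit described by the limit of > 50000 nM in this assay, at which 1 of the 3 values shown sits. Among the two numbers in hand compound 1 holds the lowest, its nearest neighbour being compound 3, with a 2.3-fold higher number from compound 1 to compound 3 (0.36 log units; beyond the scatter). The exchange at the same carbonyl carbon from compound 1 to compound 2 gives an at least 8.6-fold higher number from compound 1 to compound 2 (0.93 log units; beyond the scatter), and from compound 2 to compound 3 gives an at least 3.8-fold lower number from compound 2 to compound 3 (0.58 log units; beyond the scatter).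

Compound 4 `Nc1sc(-c2ccc(Cl)cc2)c(-c2ccc(Cl)cc2)c1C(=O)N1CCC(=O)CC1=O` has yet to be measured in this assay. It differs from compound 1 by 2,4-dioxopiperidin-1-yl in place of 4-methylpiperidin-1-yl on a carbonyl carbon. Every change so far at this carbonyl carbon has pushed the number upward from compound 1: modestly toward compound 3 with a 2.3-fold higher number from compound 1 to compound 3 (0.36 log units; beyond the scatter), and further toward compound 2 with an at least 8.6-fold higher number from compound 1 to compound 2 (0.93 log units; beyond the scatter). The move to the 2,4-dioxopiperidin-1-yl ring is therefore expected to give a step of a 3.5-fold higher number from compound 1 to compound 4 (0.54 log units; beyond the scatter) in this assay, weakening rather than strengthening. Compound 4 is accordingly estimated at 20000 nM in this assay, within a range from 6000 nM to 60000 nM, with a real chance that only a limit is returned.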

Compound 4, half-maximal inhibitory concentration: 9230 nM
Compound 4: the middle estimate sits 2.2-fold (0.34 log units) above what was measured; the range from low to high includes it.
By their numbers in this assay, from the lowest: compounds 1, 4 and 3 (each within the scatter of the next, the first and the last beyond it). At a limit, above all of these: compound 2.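

In this assay, replacing the saturated ring on this carbonyl carbon with 2,4-dioxopiperidin-1-yl, which brings 2 hydrogen-bond acceptors where 4-methylpiperidin-1-yl has 0, gives no separation from either earlier ring compound: a 1.6-fold higher number from compound 1 to compound 4 (0.21 log units; within the scatter), and a 1.4-fold lower number from compound 3 to compound 4 (0.15 log units; within the scatter). Compound 4 therefore cannot be ordered against compound 1 or compound 3, even though those two lie beyond the scatter of each other, and at this position the ring amides shown stay close together whether the ring carries a methyl group, a second nitrogen or carbonyl groups, while the anilino amide stands apart: an at least 5.4-fold lower number from compound 2 to compound 4 (0.73 log units; beyond the scatter). Compound 2 gives only a limit of the assay, not a number: the limit of > 50000 nM in this assay, at which 1 of the 4 values shown sits.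

It remains open whether the ring is needed at all, since the compounds shown do not tell whether an open-chain diethylamino group on the same carbonyl carbon would fall with the rings or with compound 2. From the compounds shown here alone, it is also open whether the separation of compound 2 goes with its aromatic ring or with its amide hydrogen, a question that a cyclohexylamino group would address.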